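The source may report more compounds than this note shows. Statements on the series, on what has been measured and on what is new or still open speak of the compounds shown alone.

Of the compounds shown here, three built on one shared core have been measured. Compound 1 `CC(=O)Nc1ccc(S(=O)(=O)Oc2ccccc2I)cc1` gives 17000 nM in a functional assay on HT-1080 cells (Homo sapiens) for antiproliferative activity, read by sulforhodamine B assay, with a stated time of 48 h; on this read-out higher numbers stand for weaker inhibition and lower numbers for stronger inhibition. Compound 2 `CC(C)C(=O)Nc1ccc(S(=O)(=O)Oc2ccccc2I)cc1` gives 3300 nM in this assay, and compound 3 `O=C(NCCCCl)Nc1ccc(S(=O)(=O)Oc2ccccc2I)cc1` gives 2800 nM. Compound 3 thus carries the lowest number of the three, although its gap to compound 2 lies within the scatter: a 1.2-fold lower number from compound 2 to compound 3 (0.07 log units; within the scatter). The two larger steps both start from compound 1: a 5.2-fold lower number from compound 1 to compound 2 (0.71 log units; beyond the scatter) and a 6.1-fold lower number from compound 1 to compound 3 (0.78 log units; beyond the scatter). Compound 1, with methyl on the carbonyl carbon, is the weakest of the set on these numbers.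

Compound 4 `O=C(NCC1CCCC1)Nc1ccc(S(=O)(=O)Oc2ccccc2I)cc1` differs from compound 3 by cyclopentyl in place of 2-chloroethyl on a saturated chain carbon bound to an amide-type nitrogen. Among the compounds with values here, no measured step alters the outer end of this chain, so the closest guide is indirect. The step from compound 2 to compound 3 exchanged one group on the carbonyl carbon for another and stayed within the scatter, while the two steps from compound 1 show that only the methyl stood apart. The change to compound 4 keeps the carbamoyl group in place and alters only its far end, so the expected step of a 1.4-fold lower number from compound 3 to compound 4 (0.15 log units; within the scatter) is small and may not reach beyond the scatter. Compound 4 is therefore expected to give 2000 nM in this assay, within a range from 700 nM to 6000 nM.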

Compound 4, half-maximal inhibitory concentration: 6100 nM
Compound 4: middle estimate off by 3.1-fold (0.48 log units), on the low side; measured number above the stated range.
By their numbers in this assay, from the lowest: compounds 3, 2 and 4 (each within the scatter of the next, the first and the last beyond it); then compound 1.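

In this assay, the outer end of the carbamoyl chain is shown to matter: cyclopentyl in place of 2-chloroethyl on a saturated chain carbon bound to an amide-type nitrogen gives a 2.2-fold higher number from compound 3 to compound 4 (0.34 log units; beyond the scatter), a modest step beyond the scatter at a place no earlier step had touched. The (cyclopentylmethyl)amino group still stands apart from methyl on the carbonyl carbon, with a 2.8-fold lower number from compound 1 to compound 4 (0.45 log units; beyond the scatter), while against isopropyl at that carbon it gives a 1.8-fold higher number from compound 2 to compound 4 (0.27 log units; within the scatter), which stays within the scatter, so the two groups cannot be ranked on these numbers. No measurement is available that explains why this exchange at the chain end changes the number.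

The compounds shown leave open whether the step follows the loss of the chlorine or the arrival of the ring, a question that a plain propyl chain or a 3-cyclopentylpropyl chain at this place could help to separate. On these data alone, how a terminal amine or a carboxylic acid at the end of this chain would read in this assay also remains open.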